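This account rests on a few compounds, and the source may have more. Where it says the series, first, only, none or still open, it means among the compounds named here.

Compound 1 `COc1cc(N2C(=O)CC2c2ccc(SC)cc2)cc(OC)c1OC`: 108 nM
Compound 2 `COc1cc(N2C(=O)C(Oc3ccccc3)C2c2ccc(SC)cc2)cc(OC)c1OC`: 336 nM
Compound 3 `CCOc1ccc(C2C(Oc3ccccc3)C(=O)N2c2cc(OC)c(OC)c(OC)c2)cc1`: 388 nM

These three compounds were tested in a functional assay on HT-29 cells (Homo sapiens) for inhibition, read by sulforhodamine B assay, with a stated time of 72 h; on this read-out higher numbers stand for weaker inhibition and lower numbers for stronger inhibition. Compound 3, at 388 nM, cannot be told apart from compound 2, as a 1.2-fold higher number from compound 2 to compound 3 (0.06 log units; within the scatter) lies within the scatter. Its number is higher than that of compound 1, at 108 nM.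

The next compound to be tested is compound 4 `CCOc1ccc(C2CC(=O)N2c2cc(OC)c(OC)c(OC)c2)cc1`. It differs from compound 3 by one change: hydrogen in place of phenoxy on a saturated ring carbon. This places hydrogen in place of phenoxy on a saturated ring carbon.

Among the compounds with values here, two measured steps bear on this change. The closest is the same exchange run in the opposite direction, phenoxy in place of hydrogen, which gave a 3.1-fold higher number from compound 1 to compound 2 (0.49 log units; beyond the scatter), a modest step beyond the scatter. The other is ethoxy in place of methylsulfanyl, which gave a 1.2-fold higher number from compound 2 to compound 3 (0.06 log units; within the scatter), so the ethoxy series may reasonably be read against the methylsulfanyl pair. This rests on a single pair, so a step of similar size toward a lower number is expected in this assay, reversing the earlier one.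

The expectation is therefore a 3.2-fold lower number from compound 3 to compound 4 (0.51 log units; beyond the scatter). For compound 4 the estimated value is 120 nM, with an expected range from 50 nM to 290 nM.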

Compound 4, half-maximal inhibitory concentration: 65 nM
Beside the measured number, compound 4's estimate is 1.8-fold (0.27 log units) above it, and the stated range covers the measured number.
By their numbers in this assay, from the lowest: compounds 4 and 1 (each within the scatter of the next); then compounds 2 and 3 (each within the scatter of the next).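

Taking the phenoxy group off the saturated ring carbon gives a 6.0-fold lower number from compound 3 to compound 4 (0.78 log units; beyond the scatter) in this assay, so the loss seen on adding phenoxy to compound 1 is not confined to the methylsulfanyl compounds and recurs with a 4-ethoxyphenyl group on the neighbouring ring atom: the same change on two cores in this assay, a 3.1-fold higher number (0.49 log units; beyond the scatter) from compound 1 to compound 2 and a 6.0-fold higher number (0.78 log units; beyond the scatter) from compound 4 to compound 3, 1.9-fold (0.28 log units) apart, within the scatter of two such steps. Within the data shown here, the exchange of methylsulfanyl for ethoxy, which had been seen only with phenoxy present, now also stays within the scatter with hydrogen in that place, at a 1.7-fold lower number from compound 1 to compound 4 (0.22 log units; within the scatter), and so these two groups cannot be told apart on either core: the same change on two cores in this assay, a 1.2-fold higher number (0.06 log units; within the scatter) from compound 2 to compound 3 and a 1.7-fold lower number (0.22 log units; within the scatter) from compound 1 to compound 4, 1.9-fold (0.28 log units) apart, within the scatter of two such steps. Across these four compounds, then, the phenoxy-for-hydrogen exchange is the change that moves the number beyond the scatter, on both cores, while the ethoxy-for-methylsulfanyl exchange does not do so on either.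

The compounds shown cover only hydrogen and phenoxy on this saturated ring carbon, so it remains open whether a hydroxyl, an amine or a methyl group there would read like hydrogen or like phenoxy. On these data alone, it also remains open whether a longer chain than ethoxy on the aromatic carbon would stay within the scatter as well.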